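Ring-Bearing Acid to Open-Chain Amide in One Urea Series

This account rests on a few compounds, and the source may have more. Where it says the series, first, only, none or still open, it means among the compounds named here.

Three ureas sharing the core of compound 1 `O=C(O)CNC(=O)Nc1ccc(F)c(C(F)(F)F)c1` have been run in an ADME assay on microsomes from liver (Homo sapiens) for metabolic stability, using NADPH, with a stated time of 60 min; on this read-out higher numbers stand for fast clearance and lower numbers for slow clearance. Compound 1 returns only a limit of the assay, < 7 uL/min. Compound 2 `O=C(Nc1ccc(F)c(C(F)(F)F)c1)NC1(C(=O)O)CC1` likewise gives only a limit, < 7 uL/min. Going by the values given here, compound 3 `O=C(Nc1ccc(F)c(C(F)(F)F)c1)NC1(C(=O)O)CCC1` is the single member with a number, giving 7 uL/min in this assay. Compound 3 therefore stands as the one readable point, while the two others rest at the limit of < 7 uL/min in this assay, at which 2 of the 3 values shown sit. The step that the two limits leave unreadable from compound 1 to compound 2 cannot be read, and the steps of a number no lower from compound 1 to compound 3 (the limit leaves the size open) and a number no lower from compound 2 to compound 3 (the limit leaves the size open) are open in size.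

Compound 4 `CC(C)(NC(=O)Nc1ccc(F)c(C(F)(F)F)c1)C(N)=O` is yet to be measured. It differs from compound 3 in the following way: 1-carbamoyl-1-methylethyl in place of 1-carboxycyclobutyl on an amide-type nitrogen. Among the compounds with values here, none of the measured steps touches this kind of exchange, since each of them moved only between carboxymethyl, 1-carboxycyclopropyl and 1-carboxycyclobutyl on the same nitrogen, and none had a readable size. With no readable precedent, the expected step for compound 4 in this assay is a 1.3-fold higher number from compound 3 to compound 4 (0.11 log units; within the scatter), which is within the scatter. Compound 4 is thus estimated at 9 uL/min, with a range from 4 uL/min to 20 uL/min, and a fair chance of again returning only a limit.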

Compound 4, intrinsic clearance in a liver preparation (reported as CLH), per the amount of preparation that the assay uses in the Homo sapiens assay: 19 uL/min
For compound 4 the middle estimate is 2.1-fold (0.32 log units) below the measured one, within the range that was stated.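

Going by these compounds alone, in the Homo sapiens assay the change from 1-carboxycyclobutyl to 1-carbamoyl-1-methylethyl on an amide-type nitrogen gives the first step of readable size at this position, a 2.7-fold higher number from compound 3 to compound 4 (0.43 log units; beyond the scatter), and the same group also sets an at least 2.7-fold higher number from compound 2 to compound 4 (0.43 log units; beyond the scatter) and an at least 2.7-fold higher number from compound 1 to compound 4 (0.43 log units; beyond the scatter), while the steps among compound 1, compound 2 and compound 3 cannot be read. In a physicochemical assay for solubility, read by nephelometry, in phosphate buffer, measured as kinetic solubility, at pH 6.5, tested at 10 mg/mL (a higher number here means a more soluble compound, a lower number a less soluble compound), compound 3 returns only a limit of the assay, > 100 ug/mL. From the compounds shown here alone, in the physicochemical assay compound 4 gives 50 ug/mL, and the pair reads as an at least 2.0-fold lower number from compound 3 to compound 4 (0.30 log units; that floor lies within the scatter), so the size of this step stays open.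

Compound 4 gives up the four-membered ring and exchanges the carboxylic acid for a carbamoyl group in a single step, and the compounds shown do not separate these two changes. A 1-carboxy-1-methylethyl group or a 1-carbamoylcyclobutyl group on the same nitrogen is the comparison that would divide them.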